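A few compounds are considered here, and "the series" means these few. Any claim that something is new, unique, unknown or untested is made for them only; others in the source may bear on it.

Compound 1 `Cc1nn(C)c(Oc2ccc(Br)cc2)c1/C=N\CCCCCOc1cc2oc(=O)cc(C)c2cc1Cl` stands at "not determined" (no result reported) in a functional assay on SMMC-7721 cells (Homo sapiens) for antiproliferative activity, read by MTT assay, with a stated time of 72 h; a lower number here means a stronger inhibitor, a higher number a weaker inhibitor. For the measured compounds named here, compound 2 `Cc1nn(C)c(Oc2cccc(F)c2)c1/C=N\CCCCCCOc1cc2oc(=O)cc(C)c2cc1Cl` gives 23600 nM in this assay, the only number so far, so nothing can be said of its rank against the others. Compound 3 `Cc1ccccc1Oc1c(/C=N\CCCCCCOc2cc3oc(=O)cc(C)c3cc2Cl)c(C)nn1C` has not been measured; it differs from compound 2 by 2-methylphenyl in place of 3-fluorophenyl on an oxygen on an aromatic ring. Going by the values given here, no step between measured compounds exists to set a direction, so the expected step of a 1.1-fold higher number from compound 2 to compound 3 (0.03 log units; within the scatter) is taken as none beyond the scatter. Compound 3 is estimated at 25000 nM, expected between 8000 nM and 80000 nM in this assay.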

Compound 3, half-maximal inhibitory concentration: 5120 nM
The estimate for compound 3 lay 4.9-fold (0.69 log units) above the measured number; the measured number lies below the stated range.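

In this assay the change to 2-methylphenyl from 3-fluorophenyl on an oxygen on an aromatic ring gives a 4.6-fold lower number from compound 2 to compound 3 (0.66 log units; beyond the scatter) and so shows that the number responds to the aryl group at this place. The step is modest and rests on one pair, and both groups are six-membered aromatic rings of carbon only with the same heavy-atom count. Nothing at hand bears on why the number moves.

As far as these compounds go, whether the step follows the methyl or the loss of fluorine remains open. So does the outcome with an unsubstituted phenyl or a pyridine ring on this oxygen.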